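The source may report more compounds than this note shows. Statements on the series, on what has been measured and on what is new or still open speak of the compounds shown alone.

Measured in a functional assay (aorta) with Rattus norvegicus as the target; a higher number here means a weaker inhibitor, a lower number a stronger inhibitor:
Compound 1 `CCO/C(O)=C1\C(COCCn2cc(N)n(C)c2=O)=NC(C)=C(C(=O)OC)C1c1ccccc1Cl` gives 25.1 nM.
Compound 2 `CCO/C(O)=C1\C(COCCn2cc(N)nc2O)=NC(C)=C(C(=O)OC)C1c1ccccc1Cl` gives 31.6 nM.
Compound 3 `CCO/C(O)=C1\C(COCCN2C(=O)CNC2=O)=NC(C)=C(C(=O)OC)C1c1ccccc1Cl` gives 31.6 nM.

Compound 1 shows the lowest of these three numbers, yet both a 1.3-fold higher number from compound 1 to compound 2 (0.10 log units; within the scatter) and a 1.3-fold higher number from compound 1 to compound 3 (0.10 log units; within the scatter) lie within the scatter, so the three compounds cannot be told apart. Compound 4 `CCO/C(O)=C1\C(COCCn2ccnn2)=NC(C)=C(C(=O)OC)C1c1ccccc1Cl` carries a further change at the same place: a group of 5 heavy atoms (2 carbon, 3 nitrogen; one five-membered aromatic ring with 3 hetero atoms) in place of a group of 8 heavy atoms (4 carbon, 3 nitrogen, 1 oxygen; one five-membered aromatic ring with 2 hetero atoms), on a saturated chain carbon, two bonds along the chain from an oxygen on a saturated carbon. The two measured steps bear directly on it, since each of them also swapped the ring group on that chain carbon, and neither moved the number beyond the scatter. The shared core appears to tolerate varied groups there. The expected step is therefore a 1.4-fold higher number from compound 1 to compound 4 (0.14 log units; within the scatter), with no change beyond the scatter in either direction. Compound 4 is estimated at 35 nM, within a range from 15 nM to 80 nM.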

Compound 4, half-maximal inhibitory concentration: 15.9 nM
Estimate against measurement, compound 4: 2.2-fold (0.34 log units) above, and the stated range covers the measured number.
By their numbers in this assay, from the lowest: compounds 4, 1, 2 and 3 (each within the scatter of the next).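

In this assay, the place on the saturated chain carbon also accepts 1H-1,2,3-triazol-1-yl, with a 1.6-fold lower number from compound 1 to compound 4 (0.20 log units; within the scatter), a 2.0-fold lower number from compound 2 to compound 4 (0.30 log units; within the scatter) and a 2.0-fold lower number from compound 3 to compound 4 (0.30 log units; within the scatter). Across these four compounds, then, the number stays within the scatter even when the group has no hydrogen-bond donors and fewer heavy atoms. Nothing available explains this result.

Every group shown here is a five-membered ring. From the compounds shown here alone, whether an open-chain amine or a carboxylic acid at this place would keep the number in the same range remains open.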